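The source may hold more compounds than are shown below. What is called first, only, known or untested is meant among the compounds shown, and "the series" means these compounds.

Compound 1, `Cc1cc(C)c(NC(=O)N(Cc2ccc(-c3n[nH]c(C)n3)cc2)C2CCCCCC2)c(C)c1`, gives in a functional assay on a cell-free system (plasma) with sterol O-acyltransferase, Soat (Rattus norvegicus) as the target; a lower number here means that less compound is needed, a higher number that more compound is needed for the effect > 1 mg/kg, which is a limit of the assay and not a number.
Compound 2, `Cc1cc(C)c(NC(=O)N(Cc2ccc(-c3ccccn3)cc2)C2CCCCCC2)c(C)c1`, gives in this assay > 1 mg/kg, again a limit rather than a number.
Compound 3, `Cc1cc(C)c(NC(=O)N(Cc2ccc(-c3ccnn3C)cc2)C2CCCCCC2)c(C)c1`, gives in this assay < 1 mg/kg, also only a limit.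

Compound 3 therefore stands at the limit of < 1 mg/kg in this assay, at which 1 of the 3 values shown sits, while the other two sit at the limit of > 1 mg/kg in this assay, at which 2 of the 3 values shown sit. The change to compound 4, `Cc1cc(C)c(NC(=O)N(Cc2ccc(-n3nccn3)cc2)C2CCCCCC2)c(C)c1`, is 2H-1,2,3-triazol-2-yl in place of 1-methyl-1H-pyrazol-5-yl on an aromatic carbon. Of the measured steps, a number no higher from compound 1 to compound 3 (the limit leaves the size open) and a number no higher from compound 2 to compound 3 (the limit leaves the size open) bear on it most closely, yet both only say that the dose did not rise; their size stays hidden behind the two limits, and a step that the two limits leave unreadable from compound 1 to compound 2 cannot be read at all. Within the data shown here, compound 1 is the one measured compound that carries a triazolyl group, and its result is > 1 mg/kg, a limit. Going back to a triazolyl ring in compound 4 is thus expected to move the dose upward, an at least 1.2-fold higher number from compound 3 to compound 4 (0.07 log units; that floor lies within the scatter), though how far is open. Compound 4 is expected to need about 1.2 mg/kg, within 0.3 mg/kg to 4 mg/kg.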

Compound 4, dose for half-maximal effect: > 1 mg/kg
Compound 4: only a limit was reported; the forecaster's own chance of this, stated with the estimate: 60%; the middle value is on the limit's open side.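

In this assay, placing 2H-1,2,3-triazol-2-yl instead of 1-methyl-1H-pyrazol-5-yl on the aromatic carbon para to a large group gives a number no lower from compound 3 to compound 4 (the limit leaves the size open). Compound 3 and compound 4 both carry a five-membered aromatic ring with no hydrogen-bond donor, so that shared feature alone does not put a compound on the same side of the limit as compound 3, which stays alone there: the limit of < 1 mg/kg in this assay, at which 1 of the 4 values shown sits. Compound 4 instead joins compound 1 and compound 2 on the other side: the limit of > 1 mg/kg in this assay, at which 3 of the 4 values shown sit.

All four results are limits, so the steps to compound 4 from compound 1 and compound 2 cannot be read, and the true distance between any of these compounds stays unknown. On these data alone, whether a methyl group on the triazole ring of compound 4, or a plain phenyl ring or a carboxylic acid at this place, would fall with compound 3 also remains open.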